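Cyano on the pyridine ring of compound 3

A few compounds are considered here, and "the series" means these few. Any claim that something is new, unique, unknown or untested is made for them only; others in the source may bear on it.

The series shares one core. In an assay on LM cells for displacement of a labelled ligand from Neuropeptide Y receptor type 5 (Homo sapiens) (on this read-out higher numbers stand for weaker inhibition and lower numbers for stronger inhibition), compound 1 `N#Cc1cccc(C2=NC(c3ccc(F)cc3)(c3ccc(F)cc3)CN2)c1` gives 2.7 nM. Compound 2 `CC(=O)c1cccc(C2=NC(c3ccc(F)cc3)(c3ccc(F)cc3)CN2)c1` gives 44 nM, and compound 3 `Fc1ccc(C2(c3ccc(F)cc3)CNC(c3ccccn3)=N2)cc1` gives 160 nM. Compound 3 stands highest of the three numbers; the nearer step is a 3.6-fold higher number from compound 2 to compound 3 (0.56 log units; beyond the scatter), the wider one a 59-fold higher number from compound 1 to compound 3 (1.77 log units; beyond the scatter).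

Compound 4 `N#Cc1cccc(C2=NC(c3ccc(F)cc3)(c3ccc(F)cc3)CN2)n1` differs from compound 3 by cyano in place of hydrogen on an aromatic carbon, that is, pyridin-2-yl becomes 6-cyanopyridin-2-yl, with the cyano on an aromatic carbon of the six-membered aromatic ring with one nitrogen, next to the ring nitrogen and meta to a large group.

Among the measured compounds shown here, two measured steps bear on this. a 59-fold higher number from compound 1 to compound 3 (1.77 log units; beyond the scatter) removes the cyano and exchanges the phenyl for a pyridine in one move; a 16-fold higher number from compound 1 to compound 2 (1.21 log units; beyond the scatter) shows how much the cyano on the phenyl is worth against acetyl, a large effect. Compound 4 brings a cyano back while keeping the pyridine of compound 3, so part of the loss between compound 1 and compound 3 is expected to be recovered. The number in this assay is expected to fall by a mid-sized step, an 8.0-fold lower number from compound 3 to compound 4 (0.90 log units; beyond the scatter), short of the full gap back to compound 1; the ring exchange alone has no separate measurement.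

For compound 4 the expected value is 20 nM, with a range from 5 nM to 80 nM.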

Compound 4, half-maximal inhibitory concentration: 39 nM
Compound 4: middle estimate off by 2.0-fold (0.29 log units), on the low side; measured number inside the range.
By their numbers in this assay, from the lowest: compound 1; then compounds 4 and 2 (each within the scatter of the next); then compound 3.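

Cyano on the pyridine ring is now measured on its own: in this assay, placing it on an aromatic carbon next to the ring nitrogen takes the number down by a modest step (a 4.1-fold lower number from compound 3 to compound 4 (0.61 log units; beyond the scatter)). The phenyl-to-pyridine exchange also gets its first reading with the cyano held in the same series, and that step stays large (a 14-fold higher number from compound 1 to compound 4 (1.16 log units; beyond the scatter)), so 6-cyanopyridin-2-yl does not match 3-cyanophenyl on this core, and the gain from cyano on the pyridine ring closes only part of the gap to compound 1. Against the acetyl compound the step lies within the scatter (a 1.1-fold lower number from compound 2 to compound 4 (0.05 log units; within the scatter)), so 6-cyanopyridin-2-yl and 3-acetylphenyl cannot be told apart on this read-out, even though compound 1 and compound 2 showed a large gap between cyano and acetyl on the phenyl ring.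

No measurement at hand accounts for any of these steps.

Open questions are whether an acetyl or a methoxy group on this same pyridine carbon would behave as it does on the phenyl ring, and whether a cyano on another carbon of the pyridine ring gives a step of similar size.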